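Bromophenyl for Trimethoxyphenyl on a Shared Core

A few compounds are considered here, and "the series" means these few. Any claim that something is new, unique, unknown or untested is made for them only; others in the source may bear on it.

Compound 1 `COc1cc(-c2nc(SCc3cn(CC(=O)NC(=O)Nc4ccccn4)nn3)nc(Nc3cccc(C(F)(F)F)c3)c2C#N)cc(OC)c1OC` was tested in a functional assay on ECa-109 cells (Homo sapiens) for inhibition, read by MTT assay, with a stated time of 72 h; on this read-out lower numbers stand for stronger inhibition and higher numbers for weaker inhibition. In this assay compound 1 gives > 64000 nM, which is a limit of the assay rather than a number. Compound 2 `COc1cc(-c2nc(SCc3cn(CC(=O)NC(=O)Nc4ccccn4)nn3)nc(Nc3ccc(Cl)cc3)c2C#N)cc(OC)c1OC` carries 4-chlorophenyl in place of 3-(trifluoromethyl)phenyl on a nitrogen on an aromatic ring. In this assay compound 2 gives > 64000 nM, also a limit. The step that the two limits leave unreadable from compound 1 to compound 2 cannot be sized because of the limit of > 64000 nM in this assay, at which 2 of the 2 values shown sit. Compound 3 `N#Cc1c(Nc2cccc(C(F)(F)F)c2)nc(SCc2cn(CC(=O)NC(=O)Nc3ccccn3)nn2)nc1-c1ccc(Br)cc1` carries 4-bromophenyl in place of 3,4,5-trimethoxyphenyl on an aromatic carbon. Within the data shown here, no measured step bears on this change, so the expected step is an at least 1.0-fold lower number from compound 1 to compound 3 (0.02 log units; that floor lies within the scatter), with a good chance of another limit. Compound 3 is estimated at 60000 nM, ranging from 5000 nM to 200000 nM.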

Compound 3, half-maximal inhibitory concentration: 2960 nM
The estimate for compound 3 lay 20-fold (1.31 log units) above the measured number, outside the stated range (below it).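

In this assay, 4-bromophenyl in place of 3,4,5-trimethoxyphenyl gives an at least 21-fold lower number from compound 1 to compound 3 (1.33 log units; beyond the scatter), the only step shown that can be read. So a change on this aromatic carbon of the shared core can bring a compound off the limit, which the earlier pair could not show. The step between compound 1 and compound 2 cannot be read, and the new step gives only a floor for the size: the limit of > 64000 nM in this assay, at which 2 of the 3 values shown sit.

From the compounds shown here alone, whether the bromine or the loss of the three methoxy groups matters more stays open. A plain phenyl or a 4-methoxyphenyl on this carbon would help to separate the two.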